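This account rests on a few compounds, and the source may have more. Where it says the series, first, only, none or still open, it means among the compounds named here.

Measured so far in a functional assay, read by spectrophotometry, with a stated time of 15 min; on this read-out lower numbers stand for stronger inhibition and higher numbers for weaker inhibition: compound 1 `COc1ccc(-c2c3ccc4ccccc4c3nc3c2c(C)nc2c4ccccc4ccc32)cc1` gives 82.3 ug/mL; compound 2 `Cc1nc2c3ccccc3ccc2c2nc3c(ccc4ccccc43)c(-c3cc(O)nc4ccccc34)c12` gives 44.8 ug/mL.

Compound 2 stands at the lowest number shown, yet the only step, a 1.8-fold lower number from compound 1 to compound 2 (0.26 log units; within the scatter), leaves it indistinguishable from compound 1. Compound 3 `Cc1nc2c3ccccc3ccc2c2nc3c(ccc4ccccc43)c(C)c12` differs from compound 2 by methyl in place of 2-hydroxyquinolin-4-yl on an aromatic carbon. That measured step swapped one aromatic substituent for another and does not bear directly on removing the aromatic substituent altogether, so the data give no basis for a step beyond the scatter; a 1.6-fold higher number from compound 2 to compound 3 (0.19 log units; within the scatter) is the expected step in this assay. Compound 3 is estimated at 70 ug/mL, in the range 30 ug/mL to 170 ug/mL.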

Compound 3, half-maximal inhibitory concentration: 89.6 ug/mL
The estimate for compound 3 lay 1.3-fold (0.11 log units) below the measured number; the range from low to high includes it.
By their numbers in this assay, from the lowest: compounds 2, 1 and 3 (each within the scatter of the next).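

Methyl in place of 2-hydroxyquinolin-4-yl gives a 2.0-fold higher number from compound 2 to compound 3 (0.30 log units; within the scatter), and methyl in place of 4-methoxyphenyl gives a 1.1-fold higher number from compound 1 to compound 3 (0.04 log units; within the scatter). On this aromatic carbon, a group of 11 heavy atoms therefore cannot be told apart from methyl, so the substituents shown here do not separate the compounds. No evidence bears on this result.

Going by these compounds, whether an amine, a carboxylic acid or a longer alkyl chain on this carbon would give a step beyond the scatter remains open. Changes elsewhere on the shared core also remain open.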